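A few compounds are considered here, and "the series" means these few. Any claim that something is new, unique, unknown or untested is made for them only; others in the source may bear on it.

Of the compounds shown here, three with a shared core have been measured in an assay on isolated protein for inhibition of Leucine-rich repeat serine/threonine-protein kinase 2 variant G2019S (Homo sapiens), read by TR-FRET and LanthaScreen, with stated times of 50 min and 30 min, in the presence of a further agent that is not named here (a higher number here means a weaker inhibitor, a lower number a stronger inhibitor), and they differ only in the group attached to the nitrogen on an aromatic ring. Compound 1 `Cc1c(Nc2nc(N)c3c(C#N)c(N4CCC[C@H]4C)n(C)c3n2)cnn1C1COC1` gives 37 nM. Compound 2 `C[C@@H]1CCCN1c1c(C#N)c2c(N)nc(Nc3cnn(C)c3)nc2n1C` gives 5 nM. Compound 3 `Cc1n[nH]cc1Nc1nc(N)c2c(C#N)c(N3CCC[C@H]3C)n(C)c2n1` gives 27 nM. Among these three numbers compound 3 stands second highest: one gap, a 1.4-fold lower number from compound 1 to compound 3 (0.14 log units; within the scatter), is inside the usual scatter, while the other gap, a 5.4-fold higher number from compound 2 to compound 3 (0.73 log units; beyond the scatter), is a real difference.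

Compound 4 `C[C@@H]1CCCN1c1c(C#N)c2c(N)nc(Nc3cn(C)nc3C(F)(F)F)nc2n1C` has not yet been measured. It differs from compound 3 by 1-methyl-3-(trifluoromethyl)-1H-pyrazol-4-yl in place of 3-methyl-1H-pyrazol-4-yl on a nitrogen on an aromatic ring. Going by the values given here, two measured steps bear on this. The step from compound 2 to compound 3, a 5.4-fold higher number from compound 2 to compound 3 (0.73 log units; beyond the scatter), shows that exchanging a 1-methyl-1H-pyrazol-4-yl for a 3-methyl-1H-pyrazol-4-yl raised the number modestly; reading it the other way, going back to a pyrazole with a methyl on its nitrogen lowers it. The step from compound 1 to compound 2, a 7.4-fold lower number from compound 1 to compound 2 (0.87 log units; beyond the scatter), points the same way. Among the compounds with values here, no measured compound carries a trifluoromethyl, so the effect of that part of the change is unknown. A modest lowering is therefore expected, a 2.3-fold lower number from compound 3 to compound 4 (0.35 log units; beyond the scatter), and compound 4 is estimated at 12 nM, with a plausible range from 3 nM to 45 nM.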

Compound 4, half-maximal inhibitory concentration: 358 nM
Beside the measured number, compound 4's estimate is 30-fold (1.47 log units) below it; measured number outside the range, above it.
By their numbers in this assay, from the lowest: compound 2; then compounds 3 and 1 (each within the scatter of the next); then compound 4.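

Going by these compounds alone, the cleanest reading is a 72-fold higher number from compound 2 to compound 4 (1.85 log units; beyond the scatter), since trifluoromethyl in place of hydrogen on an aromatic carbon is the only change: the 1-methyl-1H-pyrazol-4-yl group of compound 2 does not accept this addition without a large rise in the number. The earlier compounds shown here showed that substituted pyrazoles at this nitrogen can differ modestly, but a 13-fold higher number from compound 3 to compound 4 (1.12 log units; beyond the scatter) and a 9.7-fold higher number from compound 1 to compound 4 (0.99 log units; beyond the scatter) show that the new group costs more than either of those, leaving compound 4 as the weakest of the four, with every step to it beyond the scatter. Nothing available here accounts for this loss.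

From the compounds shown here alone, it remains open whether the rise belongs to trifluoromethyl in particular or would follow any group on that aromatic carbon, a question that a methyl, a chlorine or a single fluorine in its place would help to settle. Going by these compounds, it is also open whether the same addition would cost as much on a pyrazole carrying a longer chain, such as an ethyl or a 2-hydroxyethyl, on its nitrogen.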